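The source may report more compounds than this note shows. Statements on the series, on what has been measured and on what is new or still open speak of the compounds shown alone.

In a functional assay on cells for agonist activity at Glucose-dependent insulinotropic receptor (Homo sapiens), read by HTRF and cAMP accumulation, with a stated time of 30 min (a higher number here means that more compound is needed for the effect, a lower number that less compound is needed), the three measured compounds give these numbers:
compound 1 `CC(C)OC(=O)N1CCC2(CC1)CC(CCCOc1ccc(S(C)(=O)=O)c(F)c1)C2` gives 18 nM
compound 2 `CC(C)OC(=O)N1CCC2(CC1)CC(CCCOc1ccc(C(N)=O)c(F)c1)C2` gives 52 nM
compound 3 `CC(C)OC(=O)N1CCC2(CC1)CC(CCCOc1ccc(C(=O)NC3CC3)c(F)c1)C2` gives 8 nM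

Compound 3 stands lowest of the three, so it needs the least compound for the effect; the gaps are a 2.3-fold lower number from compound 1 to compound 3 (0.35 log units; beyond the scatter) and a 6.5-fold lower number from compound 2 to compound 3 (0.81 log units; beyond the scatter). Compound 4 `CC(C)OC(=O)N1CCC2(CC1)CC(CCCOc1ccc(C(=O)N(C)C3CC3)c(F)c1)C2` differs from compound 3 in one place: methyl in place of hydrogen on an amide-type nitrogen. Among the compounds with values here, no measured pair shows this exact change. The step that bears on it most closely, a 6.5-fold lower number from compound 2 to compound 3 (0.81 log units; beyond the scatter), also placed a group on that same amide nitrogen and lowered the number. Adding a methyl beside the cyclopropyl is a smaller change, so compound 4 is expected to move only a little, a 1.5-fold higher number from compound 3 to compound 4 (0.18 log units; within the scatter), quite possibly within the scatter. Compound 4 is therefore estimated at 12 nM, with a range from 4 nM to 40 nM.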

Compound 4, half-maximal effective concentration: 67 nM
The estimate for compound 4 lay 5.6-fold (0.75 log units) below the measured number, and the stated range ends below it.
By their numbers in this assay, from the lowest: compound 3; then compound 1; then compounds 2 and 4 (each within the scatter of the next).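

In this assay, the amide hydrogen of compound 3 proves not to be freely replaceable: methyl in its place gives an 8.4-fold higher number from compound 3 to compound 4 (0.92 log units; beyond the scatter) and wipes out the gain from cyclopropyl. The step of a 1.3-fold higher number from compound 2 to compound 4 (0.11 log units; within the scatter) leaves compound 4 level with the plain carbamoyl compound, and the step of a 3.7-fold higher number from compound 1 to compound 4 (0.57 log units; beyond the scatter) puts it on the weaker side of the methylsulfonyl compound. No measurement shown explains this loss.

On these data alone, whether an ethyl group or a cyclobutyl ring on that nitrogen, with the amide hydrogen kept, would hold the number stays open. So does the effect of methyl on the nitrogen of the plain carbamoyl.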